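Carboxyphenyl replaces methyl on the tetrazole of compound 3

The source may hold more compounds than are shown below. What is called first, only, known or untested is meant among the compounds shown, and "the series" means these compounds.

Compound 3 `CCCCCCCCc1ccc(OCC(=O)Cn2nnnc2C)cc1` was tested in an assay on microsomes from brain for inhibition of Fatty-acid amide hydrolase 1 (Rattus norvegicus), read by fluorescence and HPLC, with a stated time of 60 min (a higher number here means a weaker inhibitor, a lower number a stronger inhibitor), and gave 41 nM. Among the three measured compounds it stands second highest; compound 1 `CCCCCCCCc1ccc(OCC(=O)Cn2nnc(CCC(=O)O)n2)cc1` gives 30 nM, a neighbour within the scatter, while compound 2 `CCCCCCCCc1ccc(OCC(=O)Cn2nnc(-c3ccc(C(=O)O)cc3)n2)cc1` gives 90 nM, which lies beyond the scatter above compound 3.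

Compound 4 `CCCCCCCCc1ccc(OCC(=O)Cn2nnnc2-c2cccc(C(=O)O)c2)cc1` differs from compound 3 by a single change: 3-carboxyphenyl in place of methyl on an aromatic carbon. The group enters on an aromatic carbon of a five-membered aromatic ring with 4 nitrogen, between two ring nitrogen atoms, two ring bonds from the ring nitrogen that bears the large group.

Among the compounds with values here, the only measured step that bears on this change is a 3.0-fold higher number from compound 1 to compound 2 (0.48 log units; beyond the scatter), where a carboxyphenyl took the place of a flexible carboxylic acid chain on the same kind of ring and the number rose modestly. Compound 4 adds a carboxyphenyl where compound 3 has only a methyl, and on a different ring position, so the guidance is indirect; still, the measured data give no case of a carboxyphenyl lowering the number. An expected step of a 2.4-fold higher number from compound 3 to compound 4 (0.39 log units; beyond the scatter) in this assay, a modest rise, is therefore the best reading. Compound 4 is expected to give about 100 nM in this assay, with a likely range from 40 nM to 250 nM.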

Compound 4, half-maximal inhibitory concentration: 1800 nM
Beside the measured number, compound 4's estimate is 18-fold (1.26 log units) below it; the measured number lies above the stated range.
By their numbers in this assay, from the lowest: compounds 1 and 3 (each within the scatter of the next); then compound 2; then compound 4.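

At the aromatic carbon of the five-membered ring, next to the ring atom that bears a large group, 3-carboxyphenyl in place of methyl gives a 44-fold higher number from compound 3 to compound 4 (1.64 log units; beyond the scatter) in this assay, so this position is far from indifferent to the group it carries. The earlier step, a 3.0-fold higher number from compound 1 to compound 2 (0.48 log units; beyond the scatter), was modest, but it exchanged one acid-bearing group for another and so never set such a group against a plain methyl at this position. The new step is the first among these compounds to show a large change from a single substitution, and nothing given here accounts for its size.

The compounds shown leave open whether the large step follows from the carboxylic acid, from the six-membered aromatic ring or from the placing of the acid on that ring. An unsubstituted phenyl, a methyl ester or an amide in the same place, or the 2-carboxyethyl chain of compound 1 on this carbon, would begin to separate these parts of the change.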